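The compounds below may be only part of what the source reports. "The series", "measured", "known", "first", "only" and "open" are said of these compounds alone.

Measured so far:
Compound 1, `CC1=CCC[C@H]2[C@](C)(CC3=CC(=O)C=C(N[C@@H](C(=O)O)C(C)C)C3=O)[C@@H](C)CC[C@]12C`, gives 23800 nM in a functional assay on A549 cells (Homo sapiens) for cytotoxicity, read by MTT assay, with a stated time of 72 h; on this read-out lower numbers stand for stronger inhibition and higher numbers for weaker inhibition.
Compound 2, `CC(C)(C)C1=CC(=O)C=C(NCC(=O)O)C1=O`, gives > 200000 nM in this assay.

Of the two numbers shown, only compound 1 has a true value. As far as these compounds go, for compound 2 the result is a limit of the assay rather than a number: compound 2 sits at the limit of > 200000 nM in this assay, at which 1 of the 2 values shown sits, so its real potency is unknown beyond being weak at the highest concentration tested.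

Compound 3, `CSCC[C@H](NC1=CC(=O)C=C(C(C)(C)C)C1=O)C(=O)O`, shares the core of compound 2 and differs from it at a single place: 2-(methylsulfanyl)ethyl in place of hydrogen on a saturated chain carbon bound to an amine nitrogen and a carbonyl carbon. For the measured compounds named here, this is a small addition to a small molecule, and no measured pair in this set shows what such a change does. Since compound 2 is only a limit, any gain can only be judged against that limit; a step of an at least 1.3-fold lower number from compound 2 to compound 3 (0.12 log units; that floor lies within the scatter) is expected, that is, a modest change, if any, that may well stay within the scatter. Compound 3 is therefore estimated at 150000 nM, in the range 40000 nM to 400000 nM.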

Compound 3, half-maximal inhibitory concentration: > 200000 nM
Compound 3 ended at the assay's limit (the forecaster's own chance of this, stated with the estimate: 50%); middle value at least 1.3-fold (0.12 log units) away from the limit.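

No step can be read from compound 2 to compound 3, because both results are limits of the assay rather than true values: the limit of > 200000 nM in this assay, at which 2 of the 3 values shown sit.

The compounds shown leave open what real potency compound 2 and compound 3 have, and whether 2-(methylsulfanyl)ethyl in place of hydrogen changes that potency at all.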